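The compounds below may be only part of what the source reports. "The series", "measured", "known", "first", "only" and "open" are said of these compounds alone.

Series notes. Going by the values given here, compound 1 `Cc1cc(N2CC[C@@H](C)[C@@H](N(C)c3ncnc4[nH]ccc34)C2)n2nc(SCc3ccc(C(F)(F)F)cc3)nc2n1` is the reference point in a functional assay on MGC-803 cells (Homo sapiens) for inhibition, read by MTT assay, with a stated time of 72 h; a lower number here means a stronger inhibitor, a higher number a weaker inhibitor: compound 1 gives 2680 nM, the lowest of the three numbers measured so far. Compound 2 `Cc1cc(N2CC[C@@H](C)[C@@H](N(C)c3ncnc4[nH]ccc34)C2)n2nc(SCc3ccc([N+](=O)[O-])cc3)nc2n1` carries a nitro in place of the trifluoromethyl and gives 27000 nM in this assay; compound 3 `Cc1cc(N2CC[C@@H](C)[C@@H](N(C)c3ncnc4[nH]ccc34)C2)n2nc(SCc3ccccc3)nc2n1` carries hydrogen there and gives 5870 nM. Both departures from compound 1 raise the number, a 10-fold higher number from compound 1 to compound 2 (1.00 log units; beyond the scatter) and a 2.2-fold higher number from compound 1 to compound 3 (0.34 log units; beyond the scatter), and between the two variants a 4.6-fold lower number from compound 2 to compound 3 (0.66 log units; beyond the scatter).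

Compound 4 `Cc1ccc(CSc2nc3nc(C)cc(N4CC[C@@H](C)[C@@H](N(C)c5ncnc6[nH]ccc56)C4)n3n2)cc1` differs from compound 1 in one place: methyl in place of trifluoromethyl on an aromatic carbon. Among the compounds with values here, no measured pair shows a methyl at this carbon, so the expectation rests on the two replacements of the trifluoromethyl that are known, a 2.2-fold higher number from compound 1 to compound 3 (0.34 log units; beyond the scatter) and a 10-fold higher number from compound 1 to compound 2 (1.00 log units; beyond the scatter). Both gave higher numbers, the smaller rise for hydrogen. A methyl is a third variation at the same carbon; with only these two steps as a guide, a modest rise in the number is expected, closer in size to the hydrogen step than to the nitro step, though the scatter of this assay leaves room for no real change. Compound 4 is therefore estimated at 5000 nM in this assay, in the range 2000 nM to 12500 nM, which means an expected step of a 1.9-fold higher number from compound 1 to compound 4 (0.27 log units; within the scatter).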

Compound 4, half-maximal inhibitory concentration: 5860 nM
Beside the measured number, compound 4's estimate is 1.2-fold (0.07 log units) below it, and the stated range covers the measured number.
By their numbers in this assay, from the lowest: compound 1; then compounds 4 and 3 (each within the scatter of the next); then compound 2.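

In this assay, the step of a 1.0-fold lower number from compound 3 to compound 4 (0.00 log units; within the scatter) lies within the scatter, so compound 3 and compound 4 cannot be told apart, and a methyl at this aromatic carbon offers no measurable gain over hydrogen. The step of a 2.2-fold higher number from compound 1 to compound 4 (0.34 log units; beyond the scatter) is therefore the same size as a 2.2-fold higher number from compound 1 to compound 3 (0.34 log units; beyond the scatter), which shows that having a group at this carbon does not in itself give the lower number of compound 1: of the three groups tried here, only trifluoromethyl stands beyond the scatter from hydrogen in the favourable direction. The nitro of compound 2 remains apart from the methyl as well, a 4.6-fold lower number from compound 2 to compound 4 (0.66 log units; beyond the scatter), so the order at this carbon now rests on two separate steps from hydrogen, one up and one down, and nothing available here explains either of them.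

The compounds shown leave open whether the lower number belongs to trifluoromethyl alone or is shared by a chlorine, a methoxy group or a longer chain such as ethyl at the same carbon. They also leave open whether an amine or a carboxylic acid there would follow compound 2 or compound 1.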